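A few compounds are considered here, and "the series" means these few. Any claim that something is new, unique, unknown or untested is made for them only; others in the source may bear on it.

Working notes on the series. Among the measured compounds shown here, compound 3 `O=C(O)c1ccc(NC(=O)[C@H](C2CCCCC2)n2c(-c3ccc(Cl)cc3)nc3cc(F)c(F)cc32)c(C(F)(F)F)c1` gives 59% in a functional assay for agonist activity at Bile acid receptor (Homo sapiens), read by a luciferase reporter (a higher number here means a larger maximal response, a lower number a smaller maximal response), the highest of the three numbers so far. Compound 1 `O=C(N[C@H]1CC[C@H](C(=O)O)CC1)[C@H](C1CCCCC1)n1c(-c2ccc(Cl)nc2)nc2cc(F)c(F)cc21` gives 18% and compound 2 `O=C(O)c1cccc(NC(=O)C(C2CCCCC2)n2c(-c3ccc(Cl)cc3)nc3cc(F)c(F)cc32)c1` gives 14%; both lie below compound 3 by gaps beyond the scatter. Compound 4 `COc1cc(C(=O)O)ccc1NC(=O)[C@H](C1CCCCC1)n1c(-c2ccc(Cl)cc2)nc2cc(F)c(F)cc21` differs from compound 3 by methoxy in place of trifluoromethyl on an aromatic carbon. For the measured compounds named here, no pair of measured compounds shows this change on its own, so the size of the step has no direct precedent. Since only compound 3, carrying the trifluoromethyl, reaches a high value while compound 1 and compound 2 stay low, the expectation is a fall beyond the scatter, written as a number 24 percentage points lower from compound 3 to compound 4 (beyond the scatter), though with wide uncertainty. Compound 4 is therefore estimated at 35% in this assay, within a range from 15% to 60%.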

Compound 4, largest response reached (reported as efficacy), in percent of the reference or control that the assay uses: 32%
Estimate against measurement, compound 4: 3 percentage points above; low and high end bracket the measured number.
By their numbers in this assay, from the lowest: compounds 2 and 1 (each within the scatter of the next); then compound 4; then compound 3.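

In this assay, among the compounds shown here, methoxy in place of trifluoromethyl on this aromatic carbon gives a number 27 percentage points lower from compound 3 to compound 4 (beyond the scatter), the first direct reading of a single change at this position. The maximal response therefore depends on which of these two groups the position carries, and the swap removes a clear part of it without abolishing it. Nothing measured in this series accounts for the size or direction of this step.

Still open, going by these compounds, is whether a chlorine atom, a methyl group or a longer chain such as ethoxy on this aromatic carbon would stay near compound 3 or near compound 4. On these data alone, whether the same swap has a similar effect with other amide partners also remains open.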